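From methyl to carboxy on a chain

The source may hold more compounds than are shown below. What is called first, only, known or untested is meant among the compounds shown, and "the series" means these compounds.

Values so far in a functional assay on MKN-45 cells (Homo sapiens) for inhibition, with a stated time of 72 h (on this read-out higher numbers stand for weaker inhibition and lower numbers for stronger inhibition), for each compound
- compound 1 `COc1cc(C(=O)c2cccc3cc[nH]c23)cc(OC)c1OC` gives 210 nM
- compound 2 `CCn1ccc2cc(C(=O)c3cc(OC)c(OC)c(OC)c3)ccc21` gives 31 nM

Compound 2 stands at 31 nM as the lower of the two numbers. The gap up to compound 1 lies beyond the scatter, so compound 2 is the stronger inhibitor so far. Compound 3 `COc1cc(C(=O)c2ccc3c(ccn3CC(=O)O)c2)cc(OC)c1OC` keeps the core of compound 2 but puts carboxy in place of methyl on a saturated chain carbon bound to an aromatic nitrogen, which can also be read as ethyl to carboxymethyl. Going by the values given here, no measured pair shows this change, so what follows is a judgement. In this assay a clear move toward weaker inhibition, beyond the scatter, is expected, with a 26-fold higher number from compound 2 to compound 3 (1.41 log units; beyond the scatter) as the estimated size of that step. Compound 3 is estimated at 800 nM, with an expected range from 120 nM to 5000 nM across repeat measurements.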

Compound 3, half-maximal inhibitory concentration: 396 nM
Estimate against measurement, compound 3: 2.0-fold (0.31 log units) above, and the stated range covers the measured number.
By their numbers in this assay, from the lowest: compound 2; then compounds 1 and 3 (each within the scatter of the next).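

Going by these compounds alone, compound 3 gives the first measured change on the chain at the aromatic nitrogen. In this assay, replacing the methyl end of the ethyl group with carboxy produces a large step, a 13-fold higher number from compound 2 to compound 3 (1.11 log units; beyond the scatter), so what this chain carries clearly matters for inhibition of these cells. No measurement shown here accounts for the size of this step.

This single step cannot establish a trend across groups at this place. The compounds shown leave open how an amine, an amide or a longer chain ending in a carboxylic acid would behave on this saturated chain carbon, and whether a methyl group alone on the aromatic nitrogen would match the ethyl group of compound 2.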